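A few compounds are considered here, and "the series" means these few. Any claim that something is new, unique, unknown or untested is made for them only; others in the source may bear on it.

Compound 1 `CN1CCN(CCNCc2cn(-c3ccc([N+](=O)[O-])cc3)nc2-c2ccc(OC(F)(F)F)cc2)CC1` and compound 2 `CN1CCN(CCNCc2cn(-c3ccc(C(F)(F)F)cc3)nc2-c2ccc(OC(F)(F)F)cc2)CC1` share one core and differ in a single group. In an ADME assay on Huh-7 cells (Homo sapiens) for cytotoxicity (on this read-out higher numbers stand for lower toxicity in this test and lower numbers for higher toxicity in this test), compound 1 gives 4400 nM, and compound 2 gives 3000 nM. Among the compounds with values here, the step of a 1.5-fold lower number from compound 1 to compound 2 (0.17 log units; within the scatter) is the only measured step so far, and it tells nothing about a difference between the two compounds beyond the scatter of the test. Compound 2 thus stands at the lower of two numbers that cannot be told apart.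

Compound 3 `CN1CCN(CCNCc2cn(-c3ccc(C(F)(F)F)cc3)nc2-c2ccc(Cl)cc2)CC1` is the next compound, and it differs from compound 2 in one place: chloro in place of trifluoromethoxy on an aromatic carbon. Within the data shown here, no measured step bears on this change; the one step measured, from nitro to trifluoromethyl, sits on the other aromatic ring and changes a different group. There is therefore no basis for expecting a step beyond the scatter in this assay, in either direction, and the range around the expectation must be wide. For compound 3 the number in this assay is estimated at 3000 nM, with a range from 1000 nM to 9000 nM. This estimate means an expected step of no change at the digits printed from compound 2 to compound 3 (within the scatter), which is no change beyond the scatter.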

Compound 3, half-maximal cytotoxic concentration: 3000 nM
Estimate against measurement, compound 3: no gap at the digits printed; low and high end bracket the measured number.
By their numbers in this assay, from the lowest: compounds 2, 3 and 1 (each within the scatter of the next).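

Within the data shown here, the earlier step spoke only of the other aromatic ring, so this is the first reading at the position para to a large group. In this assay, putting chloro in place of trifluoromethoxy gives no change at the digits printed from compound 2 to compound 3 (within the scatter), even though the group that leaves has 5 heavy atoms and 1 hydrogen-bond acceptor, while the one that enters has 1 heavy atom and no acceptor. For this pair, then, the read-out does not tell 4-(trifluoromethoxy)phenyl from 4-chlorophenyl, and nothing at hand explains why the two groups give matching numbers.

As far as these compounds go, both groups carry no hydrogen-bond donor and no net charge, so it remains open whether an amine or a carboxylic acid at this position would give a number beyond the scatter of compound 2. All three compounds also lie within the scatter of their neighbours in the ranking, so these compounds do not yet show which part of the structure, if any, can move this read-out, and a longer chain in place of the side chain on the shared core is one untested possibility.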